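A few compounds are considered here, and "the series" means these few. Any claim that something is new, unique, unknown or untested is made for them only; others in the source may bear on it.

Working notes on the series, read in a functional assay on HL-60 cells (Homo sapiens) for cytotoxicity, read by WST assay, with a stated time of 48 h; on this read-out higher numbers stand for an effect only at larger amounts of compound and lower numbers for an effect already at smaller amounts. Compound 1 `COc1ccccc1C[C@H]1COC(=O)[C@@H]1Cc1ccc(Cl)c(Cl)c1` gives 14000 nM, compound 2 `O=C1OC[C@H](Cc2cccc(O)c2)[C@H]1Cc1ccc(Cl)c(Cl)c1` gives 48000 nM, and compound 3 `COc1cccc(C[C@H]2COC(=O)[C@@H]2Cc2ccc(Cl)c(Cl)c2)c1` gives 34000 nM. Compound 3 and compound 2 lie within the scatter of each other, and both numbers sit above that of compound 1, with a 2.4-fold higher number from compound 1 to compound 3 (0.39 log units; beyond the scatter) and a 3.4-fold higher number from compound 1 to compound 2 (0.54 log units; beyond the scatter).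

Next in line is compound 4 `Cc1cccc(C[C@H]2COC(=O)[C@@H]2Cc2ccc(Cl)c(Cl)c2)c1`, which has methyl in place of methoxy on an aromatic carbon, meta to a large group: methyl in place of methoxy on an aromatic carbon. Cut one bond further out, this is 3-methoxyphenyl to 3-methylphenyl.

Among the compounds with values here, no measured step makes this exact exchange. The closest is a 1.4-fold lower number from compound 2 to compound 3 (0.15 log units; within the scatter), where methyl replaces hydrogen on the oxygen of the aromatic substituent, and that step stays within the scatter. The two modest steps from compound 1 replace 2-methoxyphenyl, so they bear on the present change only loosely. Three compounds give a thin basis, but on the step from compound 2 no change beyond the scatter is expected in this assay, in either direction. The expected change is a 1.1-fold lower number from compound 3 to compound 4 (0.05 log units; within the scatter), an estimate only. The estimate for compound 4 is 30000 nM, with an expected range from 14000 nM to 65000 nM.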

Compound 4, half-maximal effective concentration: 22000 nM
The estimate for compound 4 lay 1.4-fold (0.13 log units) above the measured number, within the range that was stated.
By their numbers in this assay, from the lowest: compounds 1, 4, 3 and 2 (each within the scatter of the next, the first and the last beyond it).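

In this assay, the exchange of methoxy for methyl on this aromatic carbon, meta to a large group, can now be read directly as a 1.5-fold lower number from compound 3 to compound 4 (0.19 log units; within the scatter) and does not pass the scatter. Methyl in place of hydroxy on the same carbon gives a 2.2-fold lower number from compound 2 to compound 4 (0.34 log units; beyond the scatter) and is the only step among the hydroxy, methoxy and methyl compounds that passes the scatter, though it remains modest. The step for 3-methylphenyl in place of 2-methoxyphenyl reads a 1.6-fold higher number from compound 1 to compound 4 (0.20 log units; within the scatter) and stays within the scatter, so compound 4, unlike compound 2 and compound 3, is not separated from compound 1 by more than the scatter.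

Nothing on hand gives a reason for any of these steps. Still open, from the compounds shown here alone, is whether an amine, a carboxylic acid or a longer chain such as ethoxy on this aromatic carbon would move the number beyond the small spread seen with hydroxy, methoxy and methyl.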